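The source may hold more compounds than are shown below. What is called first, only, known or untested is meant among the compounds shown, and "the series" means these compounds.

In a functional assay on K562 cells (Homo sapiens) for inhibition, read by MTT assay, with a stated time of 48 h (on this read-out higher numbers stand for weaker inhibition and lower numbers for stronger inhibition), compound 1 (`CC(C)(C)OC(=O)N1C[C@@H](n2cc(-c3ccc(N)nc3)nn2)C[C@H]1C(=O)Nc1ccc(Cl)c(C(F)(F)F)c1`) gives 4710 nM and compound 2 (`CC(C)(C)OC(=O)N1C[C@@H](n2cc(-c3ccc4nc(N)sc4n3)nn2)C[C@H]1C(=O)Nc1ccc(Cl)c(C(F)(F)F)c1`) gives 10900 nM as the higher of the two numbers, which makes compound 2 the weaker inhibitor of the pair. Compound 3 (`CC(C)(C)OC(=O)N1C[C@@H](n2cc(-c3ccc4nc(N)sc4n3)nn2)C[C@H]1C(=O)Nc1ccc(F)c(F)c1`) has 3,4-difluorophenyl in place of 4-chloro-3-(trifluoromethyl)phenyl on an amide-type nitrogen. Among the compounds with values here, the only measured step is modest (a 2.3-fold higher number from compound 1 to compound 2 (0.36 log units; beyond the scatter)) and bears on this change only indirectly: it concerns a different group and leaves the 4-chloro-3-(trifluoromethyl)phenyl untouched. Within the data shown here, no measured compound carries 3,4-difluorophenyl, so the data offer no direct guide. That modest step is the only scale available, and in this assay no step beyond the scatter is expected, with a slight lean towards a higher number. The expected size of the change is small (a 1.4-fold higher number from compound 2 to compound 3 (0.14 log units; within the scatter)) and uncertain. For compound 3 the estimated value is 15000 nM and the expected range runs from 5000 nM to 45000 nM (wide, given the lack of direct precedent).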

Compound 3, half-maximal inhibitory concentration: 26400 nM
Beside the measured number, compound 3's estimate is 1.8-fold (0.25 log units) below it; the range from low to high includes it.
By their numbers in this assay, from the lowest: compound 1; then compound 2; then compound 3.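

Until now only the group on an aromatic carbon had varied, so the group on the amide-type nitrogen is the second place shown to move the read-out in this assay: 3,4-difluorophenyl in place of 4-chloro-3-(trifluoromethyl)phenyl gives a 2.4-fold higher number from compound 2 to compound 3 (0.38 log units; beyond the scatter), which means weaker inhibition. The step is modest but beyond the scatter, and it shows that this position does not tolerate every halogenated phenyl equally, with the entering group doing worse here than the leaving group on the same core. No measurement at hand gives a reason for this step, and one pair cannot say whether the loss follows the chlorine, the trifluoromethyl, the fluorines or the heavy-atom count.

The compounds shown leave open whether the same exchange on the amide-type nitrogen would move the number in the same direction on the core of compound 1. They also leave open how this position responds to a group of another kind, such as unsubstituted phenyl, 4-chlorophenyl or a phenyl bearing a carboxylic acid.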